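This account rests on a few compounds, and the source may have more. Where it says the series, first, only, none or still open, it means among the compounds named here.

Four related compounds are in view here, all built on one shared core. Compound 1 is `C/C(=N\NC(=O)c1cccs1)c1cnccn1`, compound 2 is `C/C(=N\NC(=O)c1ccc([N+](=O)[O-])cc1)c1cnccn1`, compound 3 is `C/C(=N\NC(=O)c1ccc(N)cc1)c1cnccn1`, and compound 4, not yet measured, is `C/C(=N\NC(=O)c1ccccc1)c1cnccn1`. In a physicochemical assay for lipophilicity (on this read-out lower numbers stand for lower lipophilicity and higher numbers for higher lipophilicity), compound 1 gives 2.6, compound 2 gives 2.1 and compound 3 gives 1.3. Compound 2 therefore sits second highest of the three numbers: compound 1 lies above it beyond the scatter, and compound 3 lies below it, further away and also beyond the scatter.

The change from compound 2 to compound 4 is hydrogen in place of nitro on an aromatic carbon. Going by the values given here, only one measured step alters a single place, and it starts from the same compound: a number 0.80 log units lower from compound 2 to compound 3 (beyond the scatter). Among the compounds with values here, that step traded nitro for amino and was modest; no measured step takes nitro away and leaves hydrogen, so it serves only as a loose guide. Within the data shown here, compound 1, carrying a different ring, is not a single-place comparison and offers no step of its own.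

Nothing here points to a large move in this assay, so the expected step from compound 2 to compound 4 is a number 0.30 log units higher from compound 2 to compound 4 (within the scatter), small and close to the scatter. The estimate for compound 4 is 2.4, expected to fall between 1.9 and 2.9.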

Compound 4, partition coefficient: 1.9
Compound 4: middle estimate off by 0.50 log units, on the high side; the measured number falls inside the stated range.
By their numbers in this assay, from the lowest: compound 3; then compounds 4 and 2 (each within the scatter of the next); then compound 1.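

In this assay, taking the nitro group off this aromatic carbon, para to a large group, and leaving hydrogen gives a number 0.20 log units lower from compound 2 to compound 4 (within the scatter), so the two compounds cannot be told apart on this read-out. Hydrogen does separate from amino at the same position, with a number 0.60 log units higher from compound 3 to compound 4 (beyond the scatter), which means that among the three groups now compared here, amino alone stands clear of the other two. Going by these compounds alone, a change at the other end of the molecule, on the carbonyl carbon, also registers, since phenyl in place of thiophen-2-yl gives a number 0.70 log units lower from compound 1 to compound 4 (beyond the scatter), and this is the first single-place comparison to include compound 1.

Still open, as far as these compounds go, is whether other groups on this aromatic carbon, such as a methyl, a carboxylic acid or a longer chain, would stay close to hydrogen and nitro or part from them as amino does, and whether the step from thiophen-2-yl to phenyl would keep its size with a substituent on the ring. Nothing available here accounts for the sizes of these steps.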